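Replacing hexyl with sec-butyl in an antiproliferative series

This account rests on a few compounds, and the source may have more. Where it says the series, first, only, none or still open, it means among the compounds named here.

In a functional assay on SW1573 cells (Homo sapiens) for antiproliferative activity, read by sulforhodamine B assay, with a stated time of 48 h (on this read-out higher numbers stand for weaker inhibition of growth and lower numbers for stronger inhibition of growth), compound 2 `CCCCCCC(C#CC(=O)OC)O/C=C/C(=O)OC` gives 3300 nM. Compound 3 `COC(=O)C#CC(CCc1ccccc1)O/C=C/C(=O)OC` gives 2600 nM, and a 1.3-fold lower number from compound 2 to compound 3 (0.10 log units; within the scatter) lies within the scatter, so these two stand level. Compound 1 `CCCCCCC(C#CC(=O)O)O/C=C/C(=O)OC` gives only a limit, > 100000 nM. The large at least 30-fold lower number from compound 1 to compound 2 (1.48 log units; beyond the scatter) arises at a different place in the molecule and does not bear on the change considered here.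

Compound 4 `CCC(C)C(C#CC(=O)OC)O/C=C/C(=O)OC` has sec-butyl in place of hexyl on a saturated chain carbon bound to an oxygen on an unsaturated carbon and a triple-bonded carbon. Among the compounds with values here, the only measured change on this chain is a 1.3-fold lower number from compound 2 to compound 3 (0.10 log units; within the scatter), which stayed within the scatter, so no step beyond the scatter is expected in this assay. The expected step is a 1.2-fold higher number from compound 2 to compound 4 (0.08 log units; within the scatter), an estimate that stays within the scatter. Within the data shown here, no measured compound carries sec-butyl, so the range is kept wide. For compound 4 the estimated value is 4000 nM, with an expected range from 1800 nM to 9000 nM.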

Compound 4, concentration for 50% growth inhibition: 910 nM
Compound 4: middle estimate off by 4.4-fold (0.64 log units), on the high side; measured number below the stated range.
By their numbers in this assay, from the lowest: compound 4; then compounds 3 and 2 (each within the scatter of the next). At a limit, above all of these: compound 1.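

The saturated chain carbon bound to an oxygen on an unsaturated carbon and a triple-bonded carbon now proves sensitive to its substituent in this assay: sec-butyl in place of hexyl gives a 3.6-fold lower number from compound 2 to compound 4 (0.56 log units; beyond the scatter), whereas the earlier change on this chain, a 1.3-fold lower number from compound 2 to compound 3 (0.10 log units; within the scatter), did not move the number beyond the scatter. Within the data shown here, this is thus the first step at this position to exceed the scatter, and it shows that the hexyl chain of compound 2 can be exchanged without loss of growth inhibition in this cell line. No measurement shown offers an explanation for this step.

The compounds shown leave open whether the step follows from the shorter chain or from its branch, which a straight butyl chain on the same carbon would help to separate. They also leave open how this position would respond to a longer branched chain or to a chain ending in an amine.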